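Side-chain exchange from compound 2 to compound 4

A few compounds are considered here, and "the series" means these few. Any claim that something is new, unique, unknown or untested is made for them only; others in the source may bear on it.

Among the compounds with values here, in a toxicity assay on HEK-293T cells (Homo sapiens) for cytotoxicity, read by MTT assay, with a stated time of 72 h (a lower number here means a stronger inhibitor, a higher number a weaker inhibitor), compound 2 `O=C1c2c[n+]([O-])c3ccccc3c2C(=O)c2c1c1ccccc1n2CCCCn1ccnc1` gives 280 nM, the lowest of the three numbers measured so far. Compound 1 `O=C1c2c[n+]([O-])c3ccccc3c2C(=O)c2c1c1ccccc1n2Cc1cn([C@H]2O[C@H](CO)[C@@H](O)[C@H]2O)nn1` gives 1370 nM, and compound 3 `CC1(C)OCC(Cn2cc(Cn3c4c(c5ccccc53)C(=O)c3c[n+]([O-])c5ccccc5c3C4=O)nn2)O1` gives 5510 nM.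

Compound 4 `CN1CCN(CCCCn2c3c(c4ccccc42)C(=O)c2c[n+]([O-])c4ccccc4c2C3=O)CC1` is still unmeasured. It carries 4-methylpiperazin-1-yl in place of 1H-imidazol-1-yl on a saturated chain carbon, four bonds along the chain from an aromatic nitrogen.

Within the data shown here, no measured step touches this group. Among the measured compounds shown here, the only single-change step, a 4.0-fold higher number from compound 1 to compound 3 (0.60 log units; beyond the scatter), is modest and concerns a different substituent, with (2,2-dimethyl-1,3-dioxolan-4-yl)methyl in place of 3,4-dihydroxy-5-(hydroxymethyl)oxolan-2-yl on an aromatic nitrogen. It gives a rough idea of the size a side-chain exchange can reach here, but no direction for the present change. The direction rests only on the position of compound 2 at 280 nM, the low end of the series, which leaves more room for an upward move. The expected step, a small rise held with little confidence, is a 1.8-fold higher number from compound 2 to compound 4 (0.25 log units; within the scatter). For compound 4 the estimated value is 500 nM, with an expected range of 150 nM to 1700 nM.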

Compound 4, half-maximal inhibitory concentration: 100 nM
Compound 4: middle estimate off by 5.0-fold (0.70 log units), on the high side, outside the stated range (below it).
By their numbers in this assay, from the lowest: compound 4; then compound 2; then compound 1; then compound 3.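

In this assay, the group on the saturated chain carbon, four bonds along the chain from an aromatic nitrogen, now has its first measured step: a 2.8-fold lower number from compound 2 to compound 4 (0.45 log units; beyond the scatter). The aromatic five-membered ring of 1H-imidazol-1-yl is therefore not needed for a low number at this place, since the six-membered non-aromatic ring of 4-methylpiperazin-1-yl gives a lower one, and the hydrogen-bond donor and acceptor counts of the two groups are the same. No measurement available here accounts for this shift.

The exchange changes ring size, aromaticity and the presence of the methyl group together, so this pair cannot show which of these differences goes with the lower number. Piperazin-1-yl without the methyl, morpholin-4-yl or piperidin-1-yl at the same place, or 4-methylpiperazin-1-yl on a shorter or longer chain, would separate these differences and show how far the step depends on the chain.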